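A few compounds are considered here, and "the series" means these few. Any claim that something is new, unique, unknown or untested is made for them only; others in the source may bear on it.

Measured compounds in a functional assay on CFPAC-1 cells (Homo sapiens) for antiproliferative activity, read by MTT assay, with a stated time of 72 h; on this read-out higher numbers stand for weaker inhibition and lower numbers for stronger inhibition:

- compound 1 `O=c1nc2oc(C3CC3)c(C#CC3CC3)c2cn1Cc1cn(-c2ccccc2F)nn1`: 54500 nM
- compound 2 `CCCCCc1ccc(C#Cc2c(-c3ccc(CCCCC)cc3)oc3nc(=O)n(Cc4cn(-c5ccccc5F)nn4)cc23)cc1`: > 100000 nM, a limit of this assay
- compound 3 `CCCCCc1ccc(C#Cc2c(-c3ccc(CCCCC)cc3)oc3nc(=O)n(Cc4cn(-c5ccc(Cl)cc5)nn4)cc23)cc1`: > 100000 nM, a limit of this assay

Among the measured compounds shown here, compound 1 is the only compound of the three with a number in this assay; the other two sit at the limit of > 100000 nM in this assay, at which 2 of the 3 values shown sit, so there is no measured step from compound 1 to any other compound. For the measured compounds named here, the one step that can be traced between measured compounds, a step that the two limits leave unreadable from compound 2 to compound 3, changes the aryl group on the aromatic nitrogen of the triazole, but both its ends are limits and its size cannot be read.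

Compound 4 `O=c1nc2oc(C3CC3)c(C#CC3CC3)c2cn1Cc1cn(Cc2ccccc2)nn1` is not yet measured. The change from compound 1 is benzyl in place of 2-fluorophenyl on an aromatic nitrogen. Going by the values given here, it touches the same aromatic nitrogen as the step from compound 2 to compound 3, but that step gives no readable size, and no other measured pair touches this position. With nothing to build on, the working expectation is no step beyond the usual scatter, that is a 1.1-fold lower number from compound 1 to compound 4 (0.04 log units; within the scatter), with wide uncertainty in both directions. Compound 4 is therefore estimated at 50000 nM in this assay, in the range 15000 nM to 160000 nM.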

Compound 4, half-maximal inhibitory concentration: 4590 nM
Beside the measured number, compound 4's estimate is 11-fold (1.04 log units) above it, and the stated range ends above it.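

In this assay, the group on this aromatic nitrogen now has a readable effect on the core of compound 1: benzyl in place of 2-fluorophenyl gives a 12-fold lower number from compound 1 to compound 4 (1.07 log units; beyond the scatter). The two groups match in heavy-atom count, in their one six-membered aromatic ring of carbon only and in having no hydrogen-bond donors or acceptors, so these counts do not separate them, and the step combines the loss of the fluorine with the change from an aryl group to benzyl. The only earlier pair changed at this nitrogen, compound 2 and compound 3, cannot be read, as both values are limits of the assay and not numbers: the limit of > 100000 nM in this assay, at which 2 of the 4 values shown sit.

Open, as far as these compounds go, is which part of the change carries the step, a question that unsubstituted phenyl and 2-fluorobenzyl on the same core would address, along with whether a longer chain such as phenethyl keeps the lower number. Also open, from the compounds shown here alone, is whether benzyl gives a readable number on the core of compound 2, with its pentyl-bearing aryl groups.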